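The source may report more compounds than this note shows. Statements on the series, on what has been measured and on what is new or still open speak of the compounds shown alone.

Values in an ADME assay on Caco-2 cells (Homo sapiens) for permeability, in the apical to basolateral direction, at pH 7.4 (on this read-out lower numbers stand for lower permeability and higher numbers for higher permeability), for the three measured compounds:

compound 1 `O=C(N[C@H]1CN(S(=O)(=O)c2ccccc2)C[C@@H]1C(=O)NC[C@@H]1CCCN1)c1cc(-c2ccccc2Cl)on1` gives 0.44 10^-6 cm/s
compound 2 `CN(C(=O)[C@H]1CN(S(=O)(=O)c2ccccc2)C[C@@H]1NC(=O)c1cc(-c2ccccc2Cl)on1)[C@H]1CCCNC1` gives 0.11 10^-6 cm/s
compound 3 `O=CN1CCC[C@H](NC(=O)[C@H]2CN(S(=O)(=O)c3ccccc3)C[C@@H]2NC(=O)c2cc(-c3ccccc3Cl)on2)C1` gives 0.96 10^-6 cm/s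

Compound 3 stands highest of the three, and its gaps to both others lie beyond the scatter. Compound 4 `CC(=O)N1CCC[C@H](NC(=O)[C@H]2CN(S(=O)(=O)c3ccccc3)C[C@@H]2NC(=O)c2cc(-c3ccccc3Cl)on2)C1` differs from it by a single small change (methyl in place of hydrogen on a carbonyl carbon), methyl in place of hydrogen on a carbonyl carbon, which reads as formyl to acetyl. Within the data shown here, no measured step makes this same change. The closest evidence is a 2.2-fold higher number from compound 1 to compound 3 (0.34 log units; beyond the scatter) and an 8.7-fold higher number from compound 2 to compound 3 (0.94 log units; beyond the scatter), both modest. Each of those steps exchanges a whole group, far more than one methyl, so they suggest only an outer limit on what might happen here. A shift beyond the scatter is therefore not expected in this assay, and neither direction is favoured. The expected step is a 1.0-fold higher number from compound 3 to compound 4 (0.02 log units; within the scatter), which stays within the scatter. For compound 4 the estimated value is 1 10^-6 cm/s, with an expected range from 0.45 10^-6 cm/s to 2.2 10^-6 cm/s.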

Compound 4, apparent permeability in the Caco-2 assay: 0.75 10^-6 cm/s
Estimate against measurement, compound 4: 1.3-fold (0.12 log units) above; the range from low to high includes it.
By their numbers in the Caco-2 assay, from the lowest: compound 2; then compounds 1, 4 and 3 (each within the scatter of the next, the first and the last beyond it).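

Among these compounds, in the Caco-2 assay, methyl in place of hydrogen on this carbonyl carbon, a change that no earlier pair isolated, gives a 1.3-fold lower number from compound 3 to compound 4 (0.11 log units; within the scatter), so formyl and acetyl cannot be told apart on this read-out. Among the compounds shown here, the acetyl compound also sits with the earlier compounds as follows in the Caco-2 assay: a 6.8-fold higher number from compound 2 to compound 4 (0.83 log units; beyond the scatter) and a 1.7-fold higher number from compound 1 to compound 4 (0.23 log units; within the scatter), the first beyond the scatter and the second within it. The same single methyl does separate the pair in lipophilicity, so a change invisible in permeability is still a measurable one in a physicochemical assay for lipophilicity, measured as octanol-water partition, at pH 7.4; on this read-out lower numbers stand for lower lipophilicity and higher numbers for higher lipophilicity: the measured distribution coefficient of compound 3, 3.1, and of compound 4, 3.5, a number 0.40 log units higher (beyond the scatter) In the physicochemical assay compound 3 gives 3.1 and compound 4 gives 3.5.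

Going by these compounds, what a longer chain such as propionyl, or an aminomethyl group, would do on this carbonyl carbon stays open in both read-outs. One pair also leaves open whether a larger rise in distribution coefficient at this place would ever appear as a shift in permeability.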